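The compounds below may be only part of what the source reports. "The series", "measured", "known", "first", "only" and "open" are said of these compounds alone.

Among the measured compounds shown here, compound 2 `Cc1cc(O)c(C2=NN(c3ccc(S(N)(=O)=O)cc3)C(/C=C/c3ccccc3)C2)cc1Cl` stands at the higher of the two numbers measured so far: in a functional assay on TK-10 cells (Homo sapiens) for antiproliferative activity, with a stated time of 48 h (on this read-out lower numbers stand for stronger inhibition of growth and higher numbers for weaker inhibition of growth), compound 2 gives 29900 nM, whereas compound 1 `Cc1cc(O)c(C2=NN(c3ccc(S(N)(=O)=O)cc3)C(c3ccccc3O)C2)cc1Cl` gives 6850 nM. Compound 3 `COc1ccc(C2CC(c3cc(Cl)c(C)cc3O)=NN2c2ccc(S(N)(=O)=O)cc2)c(OC)c1OC` differs from compound 2 by 2,3,4-trimethoxyphenyl in place of 2-phenylethenyl on a saturated ring carbon. For the measured compounds named here, only one measured step touches this position, and because a 4.4-fold higher number from compound 1 to compound 2 (0.64 log units; beyond the scatter) was modest but beyond the scatter, a change of similar size in the opposite direction seems plausible, though the new group is untested. The expected step is a 2.5-fold lower number from compound 2 to compound 3 (0.40 log units; beyond the scatter). Compound 3 is thus estimated at 12000 nM, with a range from 4000 nM to 36000 nM.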

Compound 3, concentration for total growth inhibition: 6600 nM
For compound 3 the middle estimate is 1.8-fold (0.26 log units) above the measured one, and the stated range covers the measured number.
By their numbers in this assay, from the lowest: compounds 3 and 1 (each within the scatter of the next); then compound 2.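

In this assay, the swap of 2-phenylethenyl for 2,3,4-trimethoxyphenyl gives a 4.5-fold lower number from compound 2 to compound 3 (0.66 log units; beyond the scatter). Against 2-hydroxyphenyl, the same group gives a 1.0-fold lower number from compound 1 to compound 3 (0.02 log units; within the scatter), so two differently substituted phenyl groups on this saturated ring carbon cannot be told apart, while 2-phenylethenyl stands apart from both. No measurement here explains why.

On these data alone, it remains open whether a plain phenyl, an amine or a longer alkyl chain on this carbon would match these two groups. As far as these compounds go, it is also open which of the three methoxy groups matter, if any.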